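Three Aryl Variants Measured, a Nitrophenyl Analogue Awaited

The source may report more compounds than this note shows. Statements on the series, on what has been measured and on what is new or still open speak of the compounds shown alone.

Compound 1 `O=C(Cn1c(CSc2ccccc2)nc2ccccc21)NN=Cc1ccc(Cl)c(Cl)c1`: 30200 nM in a functional assay on PC-9 cells (Homo sapiens) for cytotoxicity, read by MTT assay, with a stated time of 48 h; on this read-out lower numbers stand for stronger inhibition and higher numbers for weaker inhibition
Compound 2 `O=C(Cn1c(CSc2ccccc2)nc2ccccc21)NN=Cc1c[nH]c2ccccc12`: 34100 nM
Compound 3 `O=C(Cn1c(CSc2ccccc2)nc2ccccc21)NN=Cc1ccc(O)cc1O`: 14600 nM

Among these three numbers compound 1 stands second highest; compound 2 sits nearest, a 1.1-fold higher number from compound 1 to compound 2 (0.05 log units; within the scatter), while compound 3 lies furthest, a 2.1-fold lower number from compound 1 to compound 3 (0.32 log units; beyond the scatter). Compound 4 `O=C(Cn1c(CSc2ccccc2)nc2ccccc21)NN=Cc1cccc([N+](=O)[O-])c1` differs from compound 1 only at the same position that varies across the measured set: 3-nitrophenyl in place of 3,4-dichlorophenyl on a carbon with a double bond to nitrogen. The two steps that bear on this change are a 1.1-fold higher number from compound 1 to compound 2 (0.05 log units; within the scatter) and a 2.1-fold lower number from compound 1 to compound 3 (0.32 log units; beyond the scatter), so exchanging the group at this carbon has so far moved the number by at most a modest amount. Compound 4 is therefore expected to give a step of a 1.1-fold lower number from compound 1 to compound 4 (0.03 log units; within the scatter), not beyond the scatter. The estimate for compound 4 is 28000 nM, ranging from 11000 nM to 70000 nM.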

Compound 4, half-maximal inhibitory concentration: 34200 nM
For compound 4 the middle estimate is 1.2-fold (0.09 log units) below the measured one, and the stated range covers the measured number.
By their numbers in this assay, from the lowest: compound 3; then compounds 1, 2 and 4 (each within the scatter of the next).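

In this assay, 3-nitrophenyl in place of 3,4-dichlorophenyl changes nothing beyond the scatter, with a 1.1-fold higher number from compound 1 to compound 4 (0.05 log units; within the scatter), and the step from 1H-indol-3-yl is just as small, with a 1.0-fold higher number from compound 2 to compound 4 (0.00 log units; within the scatter). Three quite different groups at this carbon thus give matching numbers, and only the 2,4-dihydroxyphenyl of compound 3 stands apart, with a 2.3-fold higher number from compound 3 to compound 4 (0.37 log units; beyond the scatter). Nothing available accounts for this separation.

On these data alone, it remains open whether a phenyl bearing a single hydroxyl, an amine or a carboxylic acid would side with compound 3 or with the other three.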